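This account rests on a few compounds, and the source may have more. Where it says the series, first, only, none or still open, it means among the compounds named here.

In a functional assay on HCT-8 cells (Homo sapiens) for cytotoxicity, read by MTT assay, with a stated time of 24 h (on this read-out higher numbers stand for weaker inhibition and lower numbers for stronger inhibition), compound 1 (`CC[C@H](C)[C@@H](NC(=O)Cn1cc(C2=C(c3c[nH]c4ccccc34)C(=O)N(C)C2=O)c2ccccc21)C(=O)OC`) gives only > 100000 nM, which is a limit and not a number. It therefore stands at the limit of > 100000 nM in this assay, at which 1 of the 2 values shown sits. Compound 2 (`COC(=O)CCNC(=O)Cn1cc(C2=C(c3c[nH]c4ccccc34)C(=O)N(C)C2=O)c2ccccc21`) gives 50900 nM in this assay.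

Compound 3 (`COC(=O)CC[C@@H](NC(=O)Cn1cc(C2=C(c3c[nH]c4ccccc34)C(=O)N(C)C2=O)c2ccccc21)C(=O)OC`) departs from compound 1 by 2-(methoxycarbonyl)ethyl in place of sec-butyl on a saturated chain carbon bound to an amide-type nitrogen and a carbonyl carbon. In words, 2-(methoxycarbonyl)ethyl takes the place of sec-butyl on a saturated chain carbon bound to an amide-type nitrogen and a carbonyl carbon.

Among the measured compounds shown here, only one measured step bears on this change: an at least 1.9-fold lower number from compound 1 to compound 2 (0.29 log units; that floor lies within the scatter). That step also brought in 2-(methoxycarbonyl)ethyl, though on an amide-type nitrogen and in place of 1-(methoxycarbonyl)-2-methylbutyl, so it is a loose guide to the new change. Its size is also only a floor, set by the limit for compound 1.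

A small move toward lower numbers in this assay is therefore expected, resting on the step of an at least 1.9-fold lower number from compound 1 to compound 2 (0.29 log units; that floor lies within the scatter), and it may not clear the scatter. The expected size is an at least 1.5-fold lower number from compound 1 to compound 3 (0.18 log units; that floor lies within the scatter). Compound 3 is estimated at 65000 nM, with an expected range of 28000 nM to 130000 nM.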

Compound 3, half-maximal inhibitory concentration: 29200 nM
Beside the measured number, compound 3's estimate is 2.2-fold (0.35 log units) above it; low and high end bracket the measured number.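

In this assay, 2-(methoxycarbonyl)ethyl in place of sec-butyl on the saturated chain carbon bound to an amide-type nitrogen and a carbonyl carbon gives an at least 3.4-fold lower number from compound 1 to compound 3 (0.53 log units; beyond the scatter). This shows a change at this position that clears the scatter, which the floor of the earlier step, an at least 1.9-fold lower number from compound 1 to compound 2 (0.29 log units; that floor lies within the scatter), could not show, but its size is only a floor, because compound 1 stands at a limit and not at a number: the limit of > 100000 nM in this assay, at which 1 of the 3 values shown sits. The remaining step, a 1.7-fold lower number from compound 2 to compound 3 (0.24 log units; within the scatter), replaces 2-(methoxycarbonyl)ethyl with 1,3-bis(methoxycarbonyl)propyl on the amide-type nitrogen and does not separate compound 2 from compound 3 in this assay, so these two compounds give no sign that this larger group matters.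

The compounds shown leave open whether a carboxylic acid or an amine at the end of this chain would keep the number near that of compound 3, and whether a longer chain would do the same. They also leave open whether the opposite arrangement at the saturated chain carbon would give a similar number.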